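A Second Methyl on the Phenyl Ring: Expected Outcome

This account rests on a few compounds, and the source may have more. Where it says the series, first, only, none or still open, it means among the compounds named here.

Measured compounds in a functional assay on the whole organism for positive allosteric modulation, with Rattus norvegicus as the target; on this read-out higher numbers stand for an effect only at larger amounts of compound and lower numbers for an effect already at smaller amounts:
- compound 1 `Cc1nn(C)c2c1C(c1ccccc1)=NCCN2` gives 2.5 mg/kg
- compound 2 `Cc1nn(C)c2c1C(c1cccc(C(F)(F)F)c1)=NCCN2` gives 0.63 mg/kg
- compound 3 `Cc1cccc(C2=NCCNc3c2c(C)nn3C)c1` gives 2.5 mg/kg

Compound 3 sits level with compound 1 and thus, together with it, at the high end of the three numbers; compound 2 gives the lowest number, a 4.0-fold higher number from compound 2 to compound 3 (0.60 log units; beyond the scatter). Compound 4 `Cc1ccc(C)c(C2=NCCNc3c2c(C)nn3C)c1` differs from compound 3 by methyl in place of hydrogen on an aromatic carbon. Going by the values given here, the only comparable step is the one that added a methyl to compound 1: no change at the digits printed from compound 1 to compound 3 (within the scatter). A trifluoromethyl behaved differently, a 4.0-fold lower number from compound 1 to compound 2 (0.60 log units; beyond the scatter), but no trifluoromethyl enters here. The expectation is therefore a step of no change at the digits printed from compound 3 to compound 4 (within the scatter), no change beyond the scatter. Compound 4 is estimated at 2.5 mg/kg (range 1.2 mg/kg to 5 mg/kg).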

Compound 4, minimum effective dose: > 10 mg/kg
Compound 4 ended at the assay's limit (the forecaster's own chance of this, stated with the estimate: 10%); middle value at least 4.0-fold (0.60 log units) from the limit.
By their numbers in this assay, from the lowest: compound 2; then compounds 1 and 3 (each within the scatter of the next). At a limit, above all of these: compound 4.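

Methyl in place of hydrogen elsewhere on the aromatic ring gave no change at the digits printed from compound 1 to compound 3 (within the scatter) in this assay. At this place, ortho to a large group and para to a methyl group, the same change gives an at least 4.0-fold higher number from compound 3 to compound 4 (0.60 log units; beyond the scatter), so the outcome of this change depends on where on the ring it is made. The reading for compound 4 is a limit of the assay, not a number: the limit of > 10 mg/kg in this assay, at which 1 of the 4 values shown sits.

The compounds shown leave open whether a methyl at this place gives the same result without the second methyl. They also leave open how a fluorine, a methoxy or an amine would read there.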